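Acylurea-thiazole hydrazones: a fourth analogue

A few compounds are considered here, and "the series" means these few. Any claim that something is new, unique, unknown or untested is made for them only; others in the source may bear on it.

Measured so far in a functional assay on BCG823 cells (Homo sapiens) for inhibition, read by MTT assay, with a stated time of 72 h; a lower number here means a stronger inhibitor, a higher number a weaker inhibitor:
- compound 1, `CN(C(=O)NC(=O)c1ccc(Cl)cc1Cl)c1nc(C(F)(F)F)c(C(=O)N/N=C/c2ccc(C(F)(F)F)cc2)s1`: 3.08 ug/mL
- compound 2, `CN(C(=O)NC(=O)c1ccc(F)c(F)c1)c1nc(C(F)(F)F)c(C(=O)N/N=C/c2ccc([N+](=O)[O-])cc2)s1`: 2.99 ug/mL
- compound 3, `CN(C(=O)NC(=O)c1cccc([N+](=O)[O-])c1)c1nc(C(F)(F)F)c(C(=O)N/N=C/c2ccccc2C(F)(F)F)s1`: 3.97 ug/mL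

The three compounds share one core and differ only in the aryl group on the acylurea carbonyl and in the aryl group of the hydrazone. In this assay, going by the values given here, compound 3 gives the highest of the three numbers, yet its distance to compound 1 and to compound 2 is within the scatter, so no ordering among the three can be claimed; the series so far reads as flat.

The next compound, compound 4, is `CN(C(=O)NC(=O)c1ccc(F)c(F)c1)c1nc(C(F)(F)F)c(C(=O)N/N=C/c2ccccc2C(F)(F)F)s1`. It keeps the hydrazone aryl group of compound 3 and carries the acylurea aryl group of compound 2. Relative to compound 3 the change is 3,4-difluorophenyl in place of 3-nitrophenyl on a carbonyl carbon.

Both aryl groups of compound 4 already appear among the measured compounds, and the three values they sit in lie within the scatter of one another. Compound 4 is therefore expected to stay in the same band, with a step from compound 3 of a 1.2-fold lower number from compound 3 to compound 4 (0.08 log units; within the scatter), that is none beyond the scatter in either direction. The estimate for compound 4 in this assay is 3.3 ug/mL, in the range from 1.6 ug/mL to 6.6 ug/mL.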

Compound 4, half-maximal inhibitory concentration: 3.66 ug/mL
Compound 4: middle estimate off by 1.1-fold (0.04 log units), on the low side, and the stated range covers the measured number.
By their numbers in this assay, from the lowest: compounds 2, 1, 4 and 3 (each within the scatter of the next).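

In this assay, going by these compounds alone, 3,4-difluorophenyl in place of 3-nitrophenyl on a carbonyl carbon gives a 1.1-fold lower number from compound 3 to compound 4 (0.04 log units; within the scatter), the first comparison that isolates the acylurea aryl group, and this exchange leaves no readable difference. Within the data shown here, at the hydrazone aryl group, 2-(trifluoromethyl)phenyl in place of 4-nitrophenyl on a carbon with a double bond to nitrogen gives a 1.2-fold higher number from compound 2 to compound 4 (0.09 log units; within the scatter), so the second position also shows no readable difference for the one exchange available there, whereas compound 1, compound 2 and compound 3 each differ in both places and could have concealed opposing changes at the two positions. Nothing measured here bears on why either exchange leaves the number within the scatter.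

All the groups compared at both positions are substituted phenyl rings, so the flat picture rests on a narrow set of substituents and on one cell line. Still open, going by these compounds, is whether it holds with a cyclohexyl ring or a short alkyl chain on the acylurea carbonyl, or with a hydrazone aryl ring carrying an amine or a carboxylic acid.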